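Working notes on the step from compound 2 to compound 3

The compounds below may be only part of what the source reports. "The series", "measured", "known", "first", "only" and "open" are said of these compounds alone.

Measured so far in a functional assay on HepG2 cells (Homo sapiens) for cytotoxicity, read by MTT assay, with a stated time of 72 h; on this read-out lower numbers stand for stronger inhibition and higher numbers for weaker inhibition:
- compound 1 `Cc1cc(=O)n(-c2ccccc2OC(F)(F)F)nc1C(=O)Nc1ccc(Oc2ncnc3ccsc23)c(F)c1` gives 15700 nM.
- compound 2 `Cc1cc(=O)n(-c2ccccc2OC(F)(F)F)nc1C(=O)Nc1ccc(Oc2ncnc3sccc23)c(F)c1` sits at a limit of this assay, > 40000 nM.

Compound 2 is therefore known only as a limit, not as a number, and it stands at the weak end of what is shown, as the limit of > 40000 nM in this assay, at which 1 of the 2 values shown sits, records. Among the measured compounds shown here, the one measured step, an at least 2.5-fold higher number from compound 1 to compound 2 (0.40 log units; beyond the scatter), concerns the group on the ring oxygen and does not touch the part of the molecule changed here.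

Compound 3 `Cc1cc(=O)n(-c2ccc(F)c(F)c2)nc1C(=O)Nc1ccc(Oc2ncnc3sccc23)c(F)c1` differs from compound 2 by 3,4-difluorophenyl in place of 2-(trifluoromethoxy)phenyl on an aromatic nitrogen. No measured step bears on this change, so no direction beyond the scatter can be drawn from the shown compounds. With compound 2 already at the limit, compound 3 is expected to remain weak, an estimated 35000 nM (range 10000 nM to 80000 nM), which means an expected step of an at least 1.1-fold lower number from compound 2 to compound 3 (0.05 log units; that floor lies within the scatter) in this assay.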

Compound 3, half-maximal inhibitory concentration: > 40000 nM
Compound 3 ended at the assay's limit (the forecaster's own chance of this, stated with the estimate: 60%); middle value at least 1.1-fold (0.05 log units) from the limit.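

In this assay, among the compounds shown here, compound 2 and compound 3 both stand at a limit rather than a number, so no step between them can be read: the limit of > 40000 nM in this assay, at which 2 of the 3 values shown sit.

From the compounds shown here alone, whether 3,4-difluorophenyl or 2-(trifluoromethoxy)phenyl on the aromatic nitrogen gives the stronger inhibition remains open.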